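Methyl Added to the Core: Expected Growth Inhibition

The source may report more compounds than this note shows. Statements on the series, on what has been measured and on what is new or still open speak of the compounds shown alone.

Measured so far in a functional assay on MCF7 cells (Homo sapiens) for cytotoxicity, read by MTT assay, with a stated time of 72 h, tested at 1 uM; on this read-out lower numbers stand for less inhibition of growth and higher numbers for more inhibition of growth at the one concentration tested:
compound 1, `Cc1ccnc(/C(N)=N/NC(=S)N2CCOCC2)c1`, gives 1.22%
compound 2, `N/C(=N\NC(=S)N1CCCCC1)c1ccccn1`, gives 15.4%

Compound 2 stands highest of the two numbers; its nearest neighbour is compound 1, whose value lies lower by a gap beyond the usual scatter. Compound 3, `Cc1ccnc(/C(N)=N/NC(=S)N2CCCCC2)c1`, is reached from compound 2 by methyl in place of hydrogen on an aromatic carbon. Among the measured compounds shown here, no measured pair differs only in this methyl: compound 1 and compound 2 differ from each other in two places, so their two values together do not isolate what the methyl alone does. The step in this assay is therefore expected to be small, most likely downward or not beyond the scatter. Compound 3 is estimated at 10%, within 0% to 22%, which means an expected step of a number 5.4 percentage points lower from compound 2 to compound 3 (within the scatter).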

Compound 3, percent growth inhibition at one concentration: 21.2%
Beside the measured number, compound 3's estimate is 11.2 percentage points below it, within the range that was stated.
By their numbers in this assay, from the lowest: compound 1; then compounds 2 and 3 (each within the scatter of the next).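

In this assay, methyl in place of hydrogen on an aromatic carbon, opposite the ring nitrogen, leads to a number 5.8 percentage points higher from compound 2 to compound 3 (within the scatter), so the first change isolated at this position does not move the read-out beyond the scatter. With the methyl present on both compounds, piperidin-1-yl in place of morpholin-4-yl on a thiocarbonyl carbon leads to a number 20 percentage points higher from compound 1 to compound 3 (beyond the scatter), which separates this change from the methyl in a way that compound 1 and compound 2 alone could not. Nothing at hand speaks to why either step has its size.

Going by these compounds, it remains open whether an ethyl group or a methoxy group opposite the ring nitrogen would also stay within the scatter of compound 2. Also open, on these data alone, is how an amine such as piperazin-1-yl on the thiocarbonyl carbon would stand against the piperidin-1-yl of compound 3.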